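A few compounds are considered here, and "the series" means these few. Any claim that something is new, unique, unknown or untested is made for them only; others in the source may bear on it.

Measured so far in a functional assay on HCT-116 cells (Homo sapiens) for inhibition, read by sulforhodamine B assay, with a stated time of 72 h; on this read-out lower numbers stand for stronger inhibition and higher numbers for weaker inhibition:
compound 1 `CC(C)Cc1ccc(C(C)c2nnc3n2N=C(c2ccc(OC(F)(F)F)cc2)CS3)cc1` gives 3000 nM
compound 2 `CC(C)Cc1ccc(C(C)c2nnc3n2N=C(c2ccc(F)cc2)CS3)cc1` gives 12400 nM
compound 3 `CC(c1ccc(-c2ccccc2)c(F)c1)c1nnc2n1N=C(c1ccc(F)cc1)CS2` gives 10500 nM

Compound 2 shows the highest number of the three. Compound 3 stands nearest to it, and the two values lie within the scatter of each other, so no order between them is claimed. Compound 1 stands furthest away: the step of a 4.1-fold higher number from compound 1 to compound 2 (0.62 log units; beyond the scatter) lies beyond the scatter and is the one clear difference in this small set.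

Compound 4 `CC(C)Cc1ccc(C(C)c2nnc3n2N=C(c2ccc(Cl)cc2Cl)CS3)cc1` has not yet been tested. It differs from compound 2 at a single place: 2,4-dichlorophenyl in place of 4-fluorophenyl on a carbon with a double bond to nitrogen. Going by the values given here, the only measured step that touches the same ring is a 4.1-fold higher number from compound 1 to compound 2 (0.62 log units; beyond the scatter), and it concerns one group only, whereas compound 4 carries two chlorines on that ring. Among the compounds with values here, no measured pair shows chlorine here, so the reasoning rests on that single step.

Following it, compound 4 is expected to move toward a lower number, by a step of about a 2.1-fold lower number from compound 2 to compound 4 (0.32 log units; beyond the scatter). The estimate for compound 4 is 6000 nM, with a range from 2500 nM to 15000 nM.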

Compound 4, half-maximal inhibitory concentration: 11100 nM
For compound 4 the middle estimate is 1.9-fold (0.27 log units) below the measured one, and the stated range covers the measured number.
By their numbers in this assay, from the lowest: compound 1; then compounds 3, 4 and 2 (each within the scatter of the next).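

In this assay, putting 2,4-dichlorophenyl in place of 4-fluorophenyl on the carbon with a double bond to nitrogen gives a 1.1-fold lower number from compound 2 to compound 4 (0.05 log units; within the scatter), so these two compounds cannot be told apart. Going by these compounds alone, this position therefore does not answer every swap of the aromatic ring with a clear shift: two chlorines here do not produce a gap like a 4.1-fold higher number from compound 1 to compound 2 (0.62 log units; beyond the scatter), which remains the only step beyond the scatter among the compounds that differ in one place. No measured information explains why one ring swap shows a clear step while the other does not.

As far as these compounds go, whether a single chlorine on the phenyl ring would read like two chlorines remains open. So does the outcome of placing an amine or a carboxylic acid on that ring.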